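Series of trimethoxyphenyl amides: acyl chain variation

The source may report more compounds than this note shows. Statements on the series, on what has been measured and on what is new or still open speak of the compounds shown alone.

Measured compounds:
- compound 1, `C/C=C/C(=O)N(Cc1ccc(OC)c(N)c1)c1cc(OC)c(OC)c(OC)c1`, gives 300 nM in a functional assay on HCT-116 cells (Homo sapiens) for inhibition, read by MTT assay, with a stated time of 48 h; on this read-out higher numbers stand for weaker inhibition and lower numbers for stronger inhibition
- compound 2, `COc1ccc(CN(C(=O)CCCCCl)c2cc(OC)c(OC)c(OC)c2)cc1O`, gives 220 nM in this assay
- compound 3, `C/C=C/C(=O)N(Cc1ccc(OC)cc1)c1cc(OC)c(OC)c(OC)c1`, gives 500 nM in this assay

Compound 2 has the lowest of the three numbers; its gap to compound 1 is within the scatter, its gap to compound 3 lies beyond it. Compound 4, `COc1ccc(CN(C(=O)C(C)Br)c2cc(OC)c(OC)c(OC)c2)cc1O`, is not yet measured. It differs from compound 2 at the acyl chain: 1-bromoethyl in place of 4-chlorobutyl on a carbonyl carbon.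

Among the measured compounds shown here, no measured step bears on this change. For the measured compounds named here, the one step on record, a 1.7-fold higher number from compound 1 to compound 3 (0.22 log units; within the scatter), concerns the aromatic amino group, not the acyl chain. Compounds 1 and 2, which carry different acyl chains on the same amide nitrogen, give numbers within the scatter of each other, which is all that can be read from that pair. Going by the values given here, with no step on the acyl chain to lean on, no step beyond the scatter is expected in this assay, and the range is kept wide. The expected step is a 1.4-fold higher number from compound 2 to compound 4 (0.13 log units; within the scatter). Compound 4 is therefore estimated at 300 nM, within 120 nM to 800 nM.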

Compound 4, half-maximal inhibitory concentration: 140 nM
Compound 4: middle estimate off by 2.1-fold (0.33 log units), on the high side; the measured number falls inside the stated range.
By their numbers in this assay, from the lowest: compounds 4, 2, 1 and 3 (each within the scatter of the next, the first and the last beyond it).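

a 1.6-fold lower number from compound 2 to compound 4 (0.20 log units; within the scatter) is the first step on the acyl chain in this assay and stays within the scatter. On this carbonyl carbon, with the amide-type nitrogen and the rest of the core unchanged, 4-chlorobutyl (5 heavy atoms) and 1-bromoethyl (3 heavy atoms) therefore cannot be told apart on this read-out. No measured information on either chain accounts for this result.

Among the compounds shown here, the single step changes chain length and halogen together, so the contribution of each stays unseparated; 1-chloroethyl or 4-bromobutyl would divide the two. As far as these compounds go, whether the halogen is needed at all stays open, and plain ethyl or butyl chains, or a chain ending in an amine, would test this on the same core.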